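From an Ethoxy to a Hydroxy Group on a Shared Core

The source may report more compounds than this note shows. Statements on the series, on what has been measured and on what is new or still open speak of the compounds shown alone.

The study measured cytotoxicity in a toxicity assay on MDCK cells (Canis lupus familiaris) for cytotoxicity, read by CCK-8 assay, with a stated time of 48 h; on this read-out lower numbers stand for higher toxicity in this test and higher numbers for lower toxicity in this test. Within the data shown here, compound 1, with the structure `CCOc1ccc(C(=O)NNc2c(Br)cccc2Br)cc1`, is one of three compounds measured so far. In this assay compound 1 reaches only a limit of the assay, giving > 100000 nM, which is not a number. Compound 2, `CN(C)c1ccc(C(=O)NNc2c(Cl)cccc2Cl)cc1`, likewise reaches only a limit in this assay, with > 100000 nM. Compound 3, `CN(C)c1ccc(C(=O)NNc2c(F)cccc2F)cc1`, also sits at a limit in this assay, giving > 100000 nM. Thus compound 1 stands where the other two do, at the limit of > 100000 nM in this assay, at which 3 of the 3 values shown sit, and no finished number separates any of the three.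

Among the measured compounds shown here, no step between measured compounds is available, so nothing shows how a single change shifts this read-out. Compound 4, `O=C(NNc1c(Br)cccc1Br)c1ccc(O)cc1`, has not yet been measured. It differs from compound 1 by one change, (hydrogen in place of ethyl on an oxygen on an aromatic ring), so that the ethoxy becomes a hydroxy. Because all three measured compounds sit at the limit of > 100000 nM in this assay, at which 3 of the 3 values shown sit, for compound 4 the step in this assay is expected to be none beyond the scatter, a step that the limit leaves unreadable from compound 1 to compound 4. Compound 4 is therefore expected to return a limit as well, with an estimated value near 150000 nM. The estimate for compound 4 is expected to span from 50000 nM to 500000 nM.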

Compound 4, half-maximal cytotoxic concentration: > 100000 nM
Compound 4 was reported as a limit; the forecaster's own chance of this, stated with the estimate: 85%; the middle value lies beyond the limit too.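

In this assay compound 4 gives > 100000 nM as a limit and not a number. Among these compounds, compound 1 also stands at a limit, so no step from compound 1 to compound 4 can be read: the limit of > 100000 nM in this assay, at which 4 of the 4 values shown sit. The compounds shown leave open whether the change from ethoxy to hydroxy shifts this read-out at all.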